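Removing the Cyclopropylsulfonyl Group: Compound 2 to Compound 4

The compounds below may be only part of what the source reports. "The series", "measured", "known", "first", "only" and "open" are said of these compounds alone.

Three compounds have numbers in a functional assay on Urethra for agonist activity at Alpha-1A adrenergic receptor (Oryctolagus cuniculus); on this read-out higher numbers stand for higher potency (the scale is a negative logarithm) and lower numbers for lower potency. Compound 1 `CS(=O)(=O)Nc1ccc(Cl)c2c1CCCC2c1c[nH]cn1` gives 4.35. Compound 2 `O=S(=O)(Nc1cccc2c1CCCC2c1c[nH]cn1)C1CC1` gives 5.25. Compound 3 `CCS(=O)(=O)Nc1cccc(Cc2c[nH]cn2)c1` gives 6.22. Compound 2 therefore stands second highest of the three: compound 1 lies a step below it that is beyond the usual scatter, and compound 3 lies a step above it that is also beyond the scatter. Among the measured compounds shown here, no two measured compounds differ in a single place, so no one change carries a measured step of its own, and every measured compound keeps a sulfonamide.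

Compound 4 `Nc1cccc2c1CCCC2c1c[nH]cn1` is the next compound to be measured. It differs from compound 2 in one place: hydrogen in place of cyclopropylsulfonyl on a nitrogen on an aromatic ring. Put another way, the (cyclopropylsulfonyl)amino group of compound 2 becomes an amino group in compound 4.

Nothing measured here isolates the loss of the sulfonyl group, so the expectation rests on the spread of the three numbers, which already span a wide range with the sulfonamide present. The expected step in this assay is a number 0.45 log units lower from compound 2 to compound 4 (beyond the scatter), a moderate fall, with the direction uncertain. Compound 4 is estimated at 4.8, expected within 4 to 5.6.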

Compound 4, negative logarithm of the half-maximal effective concentration: 6.56
Estimate against measurement, compound 4: 1.76 log units below, and the stated range ends below it.
By their numbers in this assay, from the lowest: compound 1; then compound 2; then compound 3; then compound 4.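

In this assay, the step of a number 1.31 log units higher from compound 2 to compound 4 (beyond the scatter) is large and shows that, on this core, a sulfonyl group on the nitrogen on the aromatic ring is not required for agonist activity. Among the compounds shown here, compound 4 is the first compound here without a sulfonamide, and it stands above compound 2 rather than below it, so at this place the cyclopropylsulfonyl group lowers the read-out relative to plain hydrogen. Nothing at hand explains the size or direction of this step, and no data on any property of the two compounds bear on it.

A single pair cannot separate what the free amino group contributes from what the whole cyclopropylsulfonyl group takes away; a methylamino group, an acetamide or a smaller methylsulfonyl group at the same place would divide the step into parts. Also open, from the compounds shown here alone, is whether the same exchange gives a step of similar size and direction on the chlorinated core of compound 1 or on the core of compound 3, since this pair speaks only for the core it shares.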